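This account rests on a few compounds, and the source may have more. Where it says the series, first, only, none or still open, it means among the compounds named here.

Measured in a functional assay on SGC-7901 cells (Homo sapiens) for antiproliferative activity, read by MTT assay, with a stated time of 72 h; on this read-out lower numbers stand for stronger inhibition and higher numbers for weaker inhibition:

Compound 1, `COc1ccc(-c2c(-c3cc(OC)c(OC)c(OC)c3)ssc2=S)cc1[N+](=O)[O-]`, gives 44700 nM.
Compound 2, `COc1ccc(-c2c(-c3cc(OC)c(OC)c(OC)c3)ssc2=S)cc1N`, gives 2620 nM.
Compound 3, `COc1ccc(-c2c(-c3cc(OC)c(OC)c(OC)c3)ss/c2=N/O)cc1[N+](=O)[O-]`, gives 6560 nM.

Compound 1 and compound 2 share one core and differ by amino in place of nitro on an aromatic carbon. That single exchange brought a 17-fold lower number from compound 1 to compound 2 (1.23 log units; beyond the scatter), so the amino compound inhibits far more strongly in this assay.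

Compound 3 carries a different core; how the core of compound 3 differs from the core of compound 1 is not broken down here. Their numbers show compound 3 stronger than compound 1. Compound 4, `COc1ccc(-c2c(-c3cc(OC)c(OC)c(OC)c3)ss/c2=N/O)cc1N`, has not yet been measured. It differs from compound 3 by amino in place of nitro on an aromatic carbon, the same change as between compound 1 and compound 2, at the same place on the same ring.

Going by the values given here, because the change from compound 1 to compound 2 gave a 17-fold lower number from compound 1 to compound 2 (1.23 log units; beyond the scatter), a step of roughly similar size is expected for compound 4, although only one earlier example supports this, so somewhat less is allowed for. The expected step is a 13-fold lower number from compound 3 to compound 4 (1.12 log units; beyond the scatter). Compound 4 is estimated at 500 nM, likely between 150 nM and 2000 nM.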

Compound 4, half-maximal inhibitory concentration: 2910 nM
Estimate against measurement, compound 4: 5.8-fold (0.76 log units) below, outside the stated range (above it).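

In this assay, putting amino in place of nitro again lowers the number on the second core, with a 2.3-fold lower number from compound 3 to compound 4 (0.35 log units; beyond the scatter), so the direction of the change is the same in both pairs. The size of the change does not carry over, and the two steps differ by more than the usual scatter of such measurements: the same change on two cores in this assay, a 17-fold lower number (1.23 log units; beyond the scatter) from compound 1 to compound 2 and a 2.3-fold lower number (0.35 log units; beyond the scatter) from compound 3 to compound 4, 7.6-fold (0.88 log units) apart, beyond the scatter of two such steps. Going by these compounds alone, with only two pairs, this shows that the core can strongly alter how much this exchange matters, but it does not show why, nor what size of step another core would give.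

The compounds shown have only nitro or amino on the aromatic carbon ortho to a methoxy group. Going by these compounds, it remains open whether a hydroxyl group, an acetamide or a fluorine atom at that place would give numbers closer to those of the amino compounds or the nitro compounds on either core.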